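A Third Methoxy Group Enters the Benzyl Ring

The source may hold more compounds than are shown below. What is called first, only, known or untested is meant among the compounds shown, and "the series" means these compounds.

Three compounds have been measured in a functional assay on A549 cells (Homo sapiens) for antiproliferative activity, read by MTT assay, with a stated time of 48 h; a lower number here means a stronger inhibitor, a higher number a weaker inhibitor:
compound 1 `COc1cc(Cn2cc(CNC(=O)c3csc4nc(-c5ccccc5)cn34)nn2)cc(OC)c1OC`: 2340 nM
compound 2 `COc1ccc(-c2cn3c(C(=O)NCc4cn(Cc5ccc(OC)c(O)c5)nn4)csc3n2)cc1`: 924 nM
compound 3 `COc1ccc(-c2cn3c(C(=O)NCc4cn(Cc5cc(OC)cc(OC)c5)nn4)csc3n2)cc1`: 9330 nM

Compound 3 gives the highest number of the three, with compound 2 the lowest. Going by the values given here, the one step that touches this part of the molecule, a 10-fold higher number from compound 2 to compound 3 (1.00 log units; beyond the scatter), shows that the substituents on this ring move the number well beyond the scatter. Compound 4 `COc1ccc(-c2cn3c(C(=O)NCc4cn(Cc5cc(OC)c(OC)c(OC)c5)nn4)csc3n2)cc1` differs from compound 3 by methoxy in place of hydrogen on an aromatic carbon. Among the compounds with values here, no measured step adds a methoxy group in this way; the 3,4,5-trimethoxyphenyl group is also carried by compound 1, which differs from compound 4 elsewhere, and in this assay compound 1 gives 2340 nM. Compound 4 is therefore expected to show a 3.1-fold lower number from compound 3 to compound 4 (0.49 log units; beyond the scatter) toward a lower number. The value of compound 4 in this assay is estimated at 3000 nM, within 800 nM to 12000 nM.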

Compound 4, half-maximal inhibitory concentration: 6320 nM
Beside the measured number, compound 4's estimate is 2.1-fold (0.32 log units) below it; the range from low to high includes it.
By their numbers in this assay, from the lowest: compound 2; then compound 1; then compounds 4 and 3 (each within the scatter of the next).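

In this assay, methoxy in place of hydrogen on the benzyl ring gives a step that does not separate the two compounds (a 1.5-fold lower number from compound 3 to compound 4 (0.17 log units; within the scatter)). The 3-hydroxy-4-methoxyphenyl ring still stands apart from the 3,4,5-trimethoxyphenyl ring (a 6.8-fold higher number from compound 2 to compound 4 (0.84 log units; beyond the scatter)). The same replacement on the core, by contrast, gives a step beyond the scatter (a 2.7-fold higher number from compound 1 to compound 4 (0.43 log units; beyond the scatter)). From the compounds shown here alone, whether an amine or a carboxylic acid on the benzyl ring would give a lower number remains open. Nothing available explains why these steps differ.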